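Acid to amide on the piperidine chain, compound 2 to compound 3

The source may hold more compounds than are shown below. What is called first, only, known or untested is meant among the compounds shown, and "the series" means these compounds.

Compound 1 `CCCN1CCC(CCCn2c(COc3ccc(Cl)cc3)nc3c(C)cccc32)CC1` gives 29 nM in an assay on AV12 cells for binding affinity to Neuropeptide Y receptor type 1 (Homo sapiens); on this read-out higher numbers stand for weaker inhibition and lower numbers for stronger inhibition. Going by the values given here, compound 2 `Cc1cccc2c1nc(COc1ccc(Cl)cc1)n2CCCC1CCN(CCCC(=O)O)CC1` gives 1630 nM, the higher of the two numbers measured so far, and the one step measured, a 56-fold higher number from compound 1 to compound 2 (1.75 log units; beyond the scatter), separates it from compound 1. Compound 3 `Cc1cccc2c1nc(COc1ccc(Cl)cc1)n2CCCC1CCN(CCCC(N)=O)CC1` is not yet measured; it differs from compound 2 by amino in place of hydroxy on a carbonyl carbon. Among the compounds with values here, no measured step concerns this exchange: the only step known bears on carboxy against hydrogen at the same chain position, and it is large. Compound 3 keeps the carbonyl carbon of compound 2 but drops the hydroxy, so the number is expected to move back toward compound 1 without reaching it, and the step from compound 2 is estimated as a 6.5-fold lower number from compound 2 to compound 3 (0.81 log units; beyond the scatter). The value for compound 3 is therefore estimated at 250 nM, with a range from 50 nM to 1200 nM.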

Compound 3, inhibition constant: 88 nM
Beside the measured number, compound 3's estimate is 2.8-fold (0.45 log units) above it; measured number inside the range.
By their numbers in this assay, from the lowest: compound 1; then compound 3; then compound 2.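

In this assay, the exchange on the carbonyl carbon alone gives a 19-fold lower number from compound 2 to compound 3 (1.27 log units; beyond the scatter), so most of what was lost in a 56-fold higher number from compound 1 to compound 2 (1.75 log units; beyond the scatter) goes with the hydroxy of the carboxy group and not with the carbonyl carbon at this chain position. The position is still not neutral: carbamoyl in place of hydrogen gives a 3.0-fold higher number from compound 1 to compound 3 (0.48 log units; beyond the scatter), a modest step but beyond the scatter. Hydroxy and amino count alike in hydrogen-bond donors, acceptors and net charge, so those counts do not separate them, and nothing on hand explains the size of this step.

Going by these compounds, whether a methyl ester, an amine or an N-methyl amide at this chain end would close the remaining gap to compound 1 stays open. Also open, on these data alone, is whether a shorter or longer chain carrying the carbamoyl would do so.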